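Sulfonyl substitution and maximal tracheal response in a chromene series

A few compounds are considered here, and "the series" means these few. Any claim that something is new, unique, unknown or untested is made for them only; others in the source may bear on it.

Of the compounds shown here, three sharing one core have been measured in a functional assay on the whole organism (trachea) with Rattus norvegicus as the target; on this read-out higher numbers stand for larger maximal responses and lower numbers for smaller maximal responses. Compound 1 `CC1(C)C=C(n2ccccc2=O)c2cc(S(N)(=O)=O)ccc2O1`, with an amino group on the sulfonyl sulfur, gives 92.1% in this assay. Compound 2 `CN(C)S(=O)(=O)c1ccc2c(c1)C(n1ccccc1=O)=CC(C)(C)O2` gives 74.1%, and compound 3 `CC1(C)C=C(n2ccccc2=O)c2cc(S(=O)(=O)NC(=O)Nc3ccccc3)ccc2O1` gives 99.5%. Compound 3 stands highest of the three numbers, though its gap to compound 1 is within the scatter, while it lies beyond the scatter above compound 2.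

Compound 4 `CC1(C)C=C(n2ccccc2=O)c2cc(S(=O)(=O)Oc3ccccc3)ccc2O1` has not yet been measured. It differs from compound 3 in one place: phenoxy in place of (phenylcarbamoyl)amino on a sulfonyl sulfur.

Within the data shown here, two measured steps bear on this change. The step of a number 18 percentage points lower from compound 1 to compound 2 (beyond the scatter) shows that removing the hydrogens on the sulfonamide nitrogen went with a drop, and the step of a number 25.4 percentage points higher from compound 2 to compound 3 (beyond the scatter) shows the opposite direction when a (phenylcarbamoyl)amino group with its donors is present. The step of a number 7.4 percentage points higher from compound 1 to compound 3 (within the scatter) was within the scatter. Compound 4 keeps the aromatic ring but loses both donors, so a modest decrease is expected, roughly a number 15.5 percentage points lower from compound 3 to compound 4 (beyond the scatter) in this assay. Compound 4 is therefore estimated to give 84%, with a range from 66% to 100%.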

Compound 4, largest response reached (Emax), in percent of the reference or control that the assay uses: 86.7%
Compound 4: the middle estimate sits 2.7 percentage points below what was measured, and the stated range covers the measured number.
By their numbers in this assay, from the lowest: compound 2; then compounds 4, 1 and 3 (each within the scatter of the next, the first and the last beyond it).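

On the sulfonyl sulfur, phenoxy keeps the aromatic ring of the (phenylcarbamoyl)amino group but has no hydrogen-bond donors, and in this assay this exchange comes out as a number 12.8 percentage points lower from compound 3 to compound 4 (beyond the scatter) in a series where the amino group remains the closest comparison. Against the amino group, phenoxy gives a number 5.4 percentage points lower from compound 1 to compound 4 (within the scatter) and thus stays level with it, while against dimethylamino, which also has no hydrogen on the atom bound to sulfur, it gives a number 12.6 percentage points higher from compound 2 to compound 4 (beyond the scatter) and so shows that the absence of such a hydrogen does not alone set the number, with compound 4 going against any simple reading from compound 1 to compound 2. Nothing measured here explains why these substituents on the sulfonyl sulfur differ as they do.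

The compounds shown do not separate the aromatic ring from the atom that links it to sulfur, so a phenylamino group or a methoxy group on the sulfonyl sulfur would be the informative comparison. From the compounds shown here alone, it also remains open whether a benzyloxy group, with a longer link to the ring, would stay level with phenoxy in this assay or fall toward the dimethylamino compound.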